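Chloro for Fluoro on the Aryl Ring of Compound 2

The source may hold more compounds than are shown below. What is called first, only, known or untested is meant among the compounds shown, and "the series" means these compounds.

Measured compounds:
- compound 1, `Clc1ccc(/C=N/Nc2nc(-c3ccc(Cl)cc3)cs2)cc1`: 40%
- compound 2, `Cc1ccc(/C=N/Nc2nc(-c3ccc(F)cc3)cs2)cc1`: "not active" (no number reported)

In an in vitro assay on BTI-TN-5B1-4 cells for inhibition of Amine oxidase [flavin-containing] A (Homo sapiens), read by fluorescence, with a stated time of 15 min, tested at 100 uM (a higher number here means more inhibition at the concentration tested (going by the name of the read-out), a lower number less inhibition), compound 1 gives 40%. In this assay compound 2 is reported as "not active" (no number reported), so no single number stands for it; it is simply recorded as giving no measurable inhibition at the test concentration. Compound 2 therefore stands below compound 1 on the numbers shown, but how far below cannot be read from the data.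

Compound 3, `Cc1ccc(/C=N/Nc2nc(-c3ccc(Cl)cc3)cs2)cc1`, is not yet measured. It differs from compound 2 by chloro in place of fluoro on an aromatic carbon. Going by the values given here, compound 3 shares the chloro on the aromatic carbon with compound 1 and the methyl on the other ring with compound 2; the two values for those compounds show a gap, but no step is recorded for either pair.

Among the compounds with values here, with no comparable step recorded, the size of the change in this assay is uncertain; a modest rise from the reading of compound 2, reported as not active, is expected, though a result again at the low end of the scale is possible. Compound 3 is estimated at 18% in this assay, with a range from 0% to 42%.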

Compound 3, a percentage reported as inhibition, at one concentration (the size of the read-out at that concentration, not a potency): "not active" (no number reported)
The entry for compound 3 holds no number; there is nothing to compare the estimate with.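

In this assay compound 2 reads "not active" (no number reported) and compound 3 reads "not active" (no number reported) so no step can be read for the change from 4-fluorophenyl to 4-chlorophenyl. Nothing shown bears on this result. The compounds shown leave open how much inhibition, if any, compound 2 and compound 3 give in this assay and whether this exchange changes it.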